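Cyclopropyl at the triazole carbon: expected cytotoxicity of compound 3

A few compounds are considered here, and "the series" means these few. Any claim that something is new, unique, unknown or untested is made for them only; others in the source may bear on it.

Working notes on two measured compounds and one unmeasured. Compound 1 `COc1nc2ccc(Br)cc2cc1C(c1ccccc1)n1cc(-c2ccccc2)nn1` gives, in an ADME assay on PC-3 cells (Homo sapiens) for cytotoxicity, read by sulforhodamine B assay, with a stated time of 48 h, tested at 10 uM (a lower number here means less inhibition, a higher number more inhibition at the concentration tested (going by the name of the read-out)), a value of 5.97%. Compound 2 `CCCc1cn(C(c2ccccc2)c2cc3cc(Br)ccc3nc2OC)nn1` gives in this assay a value of 8.3%. Going by the values given here, compound 1 stands alongside compound 2, the only other measured compound; the step of a number 2.3 percentage points higher from compound 1 to compound 2 (within the scatter), propyl in place of phenyl on an aromatic carbon, lies within the scatter, so the two numbers cannot be ordered.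

Compound 3 `COc1nc2ccc(Br)cc2cc1C(c1ccccc1)n1cc(C2CC2)nn1` differs from compound 1 as follows: cyclopropyl in place of phenyl on an aromatic carbon. Among the compounds with values here, the only step that bears on it is the one from compound 1 to compound 2, which exchanged the same phenyl for another saturated carbon group at the same place and moved the read-out only within the scatter. On that basis the exchange for cyclopropyl is expected to give no step beyond the scatter in this assay, so a number 1 percentage points higher from compound 1 to compound 3 (within the scatter) is the expected change. Compound 3 is therefore estimated at 7%, within 0% to 18%.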

Compound 3, a percentage reported as inhibition, at one concentration (the size of the read-out at that concentration, not a potency): 22.6%
The estimate for compound 3 lay 15.6 percentage points below the measured number, outside the stated range (above it).
By their numbers in this assay, from the lowest: compounds 1 and 2 (each within the scatter of the next); then compound 3.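

In this assay, the group on this aromatic carbon does matter: cyclopropyl in place of phenyl gives a number 16.6 percentage points higher from compound 1 to compound 3 (beyond the scatter), and cyclopropyl in place of propyl gives a number 14.3 percentage points higher from compound 2 to compound 3 (beyond the scatter). Propyl in place of phenyl produced no step beyond the scatter, so the higher number goes with cyclopropyl in particular and not with the loss of phenyl alone. Nothing available accounts for this difference.

Going by these compounds, it remains open whether other small carbon groups at this place, such as cyclobutyl or isopropyl, follow cyclopropyl or stay with propyl, and whether a group carrying an amine or a hydroxyl would move the number at all. Also open, on these data alone, is whether the same step would appear with a core other than that of compound 1.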